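The compounds below may be only part of what the source reports. "The series", "measured", "known", "first", "only" and "open" are said of these compounds alone.

Compound 1 `O=C(Nc1ccc(N(CC2CC2)CC2CC2)cc1Cl)c1cc(Cl)ccc1O` is the reference point of this short series. In an ADME assay on A549 cells (Homo sapiens) for cytotoxicity, read by resazurin assay, with a stated time of 48 h (a lower number here means that less compound is tolerated, a higher number that more compound is tolerated), compound 1 gives 12800 nM, the lowest of the two numbers recorded so far. Within the data shown here, its only measured neighbour is compound 2 `CC(CCO)Nc1ccc(NC(=O)c2cc(Cl)ccc2O)c(Cl)c1`, which in this assay gives 200000 nM; the step of a 16-fold higher number from compound 1 to compound 2 (1.19 log units; beyond the scatter) is large and lies beyond the scatter, and it comes from putting (3-hydroxy-1-methylpropyl)amino in place of bis(cyclopropylmethyl)amino on an aromatic carbon. Compound 3 `O=C(Nc1ccc(NCCCO)cc1Cl)c1cc(Cl)ccc1O` is the next candidate, differing from compound 1 as follows: (3-hydroxypropyl)amino in place of bis(cyclopropylmethyl)amino on an aromatic carbon. Among the measured compounds shown here, this change closely resembles the one that separates compound 1 from compound 2, so that single step is the only guide available. Because of the size of a 16-fold higher number from compound 1 to compound 2 (1.19 log units; beyond the scatter) for compound 2, a similarly large upward step is expected here, namely a 7.8-fold higher number from compound 1 to compound 3 (0.89 log units; beyond the scatter). Compound 3 is therefore estimated to give 100000 nM in this assay, within a range from 30000 nM to 300000 nM.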

Compound 3, half-maximal cytotoxic concentration: 106000 nM
The estimate for compound 3 lay 1.1-fold (0.03 log units) below the measured number; the measured number falls inside the stated range.
By their numbers in this assay, from the lowest: compound 1; then compounds 3 and 2 (each within the scatter of the next).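

In this assay, among these compounds, a second, different chain in place of bis(cyclopropylmethyl)amino on this aromatic carbon also gives a higher number, with an 8.3-fold higher number from compound 1 to compound 3 (0.92 log units; beyond the scatter) on record, so the upward shift at this position is not confined to the single group in compound 2. The methyl on the chain of compound 2 makes no difference that can be told apart, as a 1.9-fold lower number from compound 2 to compound 3 (0.28 log units; within the scatter) stays inside the usual spread of repeated measurements. Nothing measured here accounts for the shift at this position.

The compounds shown leave open whether a simple propylamino group without the hydroxy, a chain ending in an amine or a carboxylic acid, or a longer chain would fall with compound 1 or with compound 2 and compound 3. In both steps away from compound 1 the cyclopropyl rings leave as the hydroxy group enters, so these two changes remain unseparated.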